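Compound 3 to compound 4: pyridin-2-yl replacing benzyl

A few compounds are considered here, and "the series" means these few. Any claim that something is new, unique, unknown or untested is made for them only; others in the source may bear on it.

In a functional assay on MGC-803 cells (Homo sapiens) for inhibition, read by MTT assay, with a stated time of 48 h (a higher number here means a weaker inhibitor, a lower number a stronger inhibitor), compound 1 `COc1ccc(-c2coc3cc(OCCCBr)ccc3c2=O)cc1` gives 64900 nM, compound 2 `COc1ccc(-c2coc3cc(OCCCCSC(=S)N4CCN(C(=O)OC(C)(C)C)CC4)ccc3c2=O)cc1` gives 31300 nM and compound 3 `COc1ccc(-c2coc3cc(OCCCSC(=S)N4CCN(Cc5ccccc5)CC4)ccc3c2=O)cc1` gives 43800 nM. Compound 3 holds the second highest of the three numbers, and its gaps to compound 2 and compound 1 both lie within the scatter. Going by the values given here, no two measured compounds differ in one place only, so the effect of a single change has not been isolated.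

The next compound is compound 4 `COc1ccc(-c2coc3cc(OCCCSC(=S)N4CCN(c5ccccn5)CC4)ccc3c2=O)cc1`, with pyridin-2-yl in place of benzyl on an amine nitrogen in a ring. Different groups sit on that ring in compound 2 at 31300 nM and compound 3 at 43800 nM, yet these two values remain within the scatter of each other. In this assay, a small move towards a lower number is therefore expected, with no step beyond the scatter. The estimate amounts to an expected 1.5-fold lower number from compound 3 to compound 4 (0.16 log units; within the scatter). Compound 4 is estimated at 30000 nM, with an expected range of 10000 nM to 70000 nM.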

Compound 4, half-maximal inhibitory concentration: 42000 nM
Beside the measured number, compound 4's estimate is 1.4-fold (0.15 log units) below it; low and high end bracket the measured number.
By their numbers in this assay, from the lowest: compounds 2, 4, 3 and 1 (each within the scatter of the next, the first and the last beyond it).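

In this assay, going by these compounds alone, pyridin-2-yl in place of benzyl on the amine nitrogen in the ring gives a 1.0-fold lower number from compound 3 to compound 4 (0.02 log units; within the scatter), the first step that isolates a single change. At this position, the two groups are not told apart in this assay, although the change swaps a carbon-only aromatic ring for one with a hetero atom and adds a hydrogen-bond acceptor. Nothing measured is available to explain this result.

From the compounds shown here alone, it remains open whether a methyl, an acetyl or a carboxylic acid-bearing aryl group on that nitrogen would give a step beyond the scatter. Compound 2 differs from compound 3 and compound 4 in more than one place, so the separate contribution of the chain joining the core to the dithiocarbamate remains unresolved.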